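Dechlorination Across Two Cores in a Cytotoxicity Series

This account rests on a few compounds, and the source may have more. Where it says the series, first, only, none or still open, it means among the compounds named here.

The study compares two cores carrying a chloro group and their dechlorinated partners in a functional assay on LM7 cells (Homo sapiens) for cytotoxicity, read by MTT assay, with a stated time of 72 h; on this read-out higher numbers stand for weaker inhibition and lower numbers for stronger inhibition. Compound 1 `Cc1nnc(SCc2coc3ccc(Cl)cc3c2=O)o1` gives 8700 nM in this assay. Compound 3 `Cc1nnc(SCc2coc3ccccc3c2=O)o1` shares its core and differs by hydrogen in place of chloro on an aromatic carbon, and in this assay compound 3 gives 3500 nM. For the measured compounds named here, that step, a 2.5-fold lower number from compound 1 to compound 3 (0.40 log units; beyond the scatter), is the only measured example of this change. Compound 2 `Cc1cc(C)n2nc(SCc3cc(=O)c4cc(Cl)ccc4o3)nc2n1` is built on a different core; how its core differs from that of compound 1 is not broken down here. In this assay compound 2 reaches only the limit > 25000 nM, and the reading at the limit of > 25000 nM in this assay, at which 1 of the 3 values shown sits, means no number was obtained. Compound 4 `Cc1cc(C)n2nc(SCc3cc(=O)c4ccccc4o3)nc2n1` is the dechlorinated partner of compound 2, differing by hydrogen in place of chloro on an aromatic carbon, which is the same change as between compound 1 and compound 3. Compound 4 is expected to show a step of an at least 1.2-fold lower number from compound 2 to compound 4 (0.09 log units; that floor lies within the scatter), resting on the step of a 2.5-fold lower number from compound 1 to compound 3 (0.40 log units; beyond the scatter) seen with compound 1 and compound 3. Compound 4 is therefore estimated at 20000 nM, within 8000 nM to 50000 nM.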

Compound 4, half-maximal inhibitory concentration: > 25000 nM
Compound 4 was reported as a limit; the forecaster's own chance of this, stated with the estimate: 45%; middle value at least 1.2-fold (0.09 log units) away from the limit.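

No step can be read from compound 2 to compound 4, because both compounds sit at the same limit, which is not a number: the limit of > 25000 nM in this assay, at which 2 of the 4 values shown sit.

The compounds shown leave open whether hydrogen in place of chloro on an aromatic carbon shifts the number at all on the core of compound 2, as it does between compound 1 and compound 3.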